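A Second Hydroxy on the Pendant Phenyl Ring

This account rests on a few compounds, and the source may have more. Where it says the series, first, only, none or still open, it means among the compounds named here.

Compound 2 `O=c1oc2c(O)c(O)ccc2cc1-c1ccc(O)cc1` and compound 1 `O=c1oc2c(O)c(O)ccc2cc1-c1ccccc1` share one core and differ only on the pendant phenyl ring. In an assay on CHO cells for displacement of a labelled ligand from adenosine receptor A1 (Homo sapiens), read by radioligand binding (on this read-out higher numbers stand for weaker inhibition and lower numbers for stronger inhibition), compound 1 gives 2400 nM, and compound 2 gives 12500 nM, the higher of the two numbers shown. Going by the values given here, the only measured step, a 5.2-fold higher number from compound 1 to compound 2 (0.72 log units; beyond the scatter), shows that a hydroxy on that ring went with weaker inhibition. Compound 3 `O=c1oc2c(O)c(O)ccc2cc1-c1ccc(O)c(O)c1` carries one hydroxy more: the change is hydroxy in place of hydrogen on an aromatic carbon. Among the compounds with values here, no measured pair covers a hydroxy ortho to a hydroxy group, so the single known step is the only guide. Because a 5.2-fold higher number from compound 1 to compound 2 (0.72 log units; beyond the scatter) was modest yet beyond the scatter, a further step in the same direction, of similar or somewhat smaller size, is expected. The estimate for compound 3 in this assay is therefore 25000 nM, between 8000 nM and 80000 nM, which means an expected step of a 2.0-fold higher number from compound 2 to compound 3 (0.30 log units; within the scatter).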

Compound 3, inhibition constant: 6280 nM
Compound 3: middle estimate off by 4.0-fold (0.60 log units), on the high side; measured number below the stated range.
By their numbers in this assay, from the lowest: compound 1; then compounds 3 and 2 (each within the scatter of the next).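

In this assay the second hydroxy on the pendant ring, ortho to a hydroxy group, goes with a 2.0-fold lower number from compound 2 to compound 3 (0.30 log units; within the scatter) and so cannot be told apart from no change. The first hydroxy on that ring went with a 5.2-fold higher number from compound 1 to compound 2 (0.72 log units; beyond the scatter) and lay beyond the scatter, so the same swap of hydrogen for hydroxy does not behave alike at these two places: the drop in inhibition seen with the first hydroxy is not seen again with the second.

On these data alone, whether a methoxy or an amine in this same place would also leave the number within the scatter remains open. So does whether a hydroxy on another carbon of this ring would read like compound 3. Nothing further is at hand that would explain this result.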